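The source may hold more compounds than are shown below. What is called first, only, known or untested is meant among the compounds shown, and "the series" means these compounds.

Compound 3 `Nc1ccc(COc2ccc(OCCOCCNC3CCCC3)cc2)cc1` stands alongside compound 1 `c1ccc(COc2ccc(OCCOCCNc3ccncc3)cc2)cc1` and compound 2 `c1ccc(COc2ccc(OCCOCCNc3cc[nH]c3)cc2)cc1` in a small series sharing the same core. In a functional assay on SK-OV-3 cells (Homo sapiens) for inhibition, read by CCK-8 assay, with a stated time of 70 h (on this read-out higher numbers stand for weaker inhibition and lower numbers for stronger inhibition), compound 3 gives 31700 nM, compound 1 gives 20600 nM, and compound 2 gives 11300 nM. Compound 3 thus carries the highest of the three numbers; its gap to compound 1 lies within the scatter, while its gap to compound 2 lies beyond it. Within the data shown here, the only measured step, a 1.8-fold lower number from compound 1 to compound 2 (0.26 log units; within the scatter), concerns the group on the amine nitrogen and is itself within the scatter. Compound 4 `O=C(O)c1ccc(COc2ccc(OCCOCCNC3CCCC3)cc2)cc1` differs from compound 3 in another part of the molecule: carboxy in place of amino on an aromatic carbon. The same difference, cut one bond further out, reads 4-aminophenyl to 4-carboxyphenyl. Among the measured compounds shown here, no measured pair alters this part of the molecule, so the change has no direct precedent here, and the one step that does exist is small. Compared with compound 3, compound 4 is expected to show a step of a 1.1-fold lower number from compound 3 to compound 4 (0.02 log units; within the scatter) in this assay, nothing beyond the scatter. Compound 4 is therefore estimated at 30000 nM, ranging between 10000 nM and 90000 nM.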

Compound 4, half-maximal inhibitory concentration: > 100000 nM
Compound 4: only a limit was reported (the forecaster's own chance of this, stated with the estimate: 10%); middle value at least 3.3-fold (0.52 log units) away from the limit.
By their numbers in this assay, from the lowest: compounds 2, 1 and 3 (each within the scatter of the next, the first and the last beyond it). At a limit, above all of these: compound 4.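

In this assay compound 4 is reported only as a limit (> 100000 nM), not as a number. Carboxy in place of amino on the aromatic carbon is the first change shown at this end of the molecule, and unlike the one earlier step, on the amine nitrogen, which stayed within the scatter, it moves the read-out beyond the scatter (an at least 3.1-fold higher number from compound 3 to compound 4 (0.49 log units; beyond the scatter)). This position is therefore not indifferent to what it carries: of the two groups shown here, carboxy gives the weaker inhibition.

As far as these compounds go, because compound 4 stands at a limit, the full size of this step stays unknown. From the compounds shown here alone, whether a methyl ester, a primary amide or a hydroxymethyl group at this position, or a carboxylic acid on a longer chain, would stay close to compound 3 or follow compound 4 remains open.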